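Azido in Place of Hydrogen: What Compound 4 May Show

The compounds below may be only part of what the source reports. "The series", "measured", "known", "first", "only" and "open" are said of these compounds alone.

Compound 1 `Cc1cccc2c1nc(-c1c(F)cccc1F)n2Cc1c(F)cccc1F` is the point of departure. In a toxicity assay on CCRF-CEM cells (Homo sapiens) for cytotoxicity (on this read-out lower numbers stand for higher toxicity in this test and higher numbers for lower toxicity in this test), compound 1 gives > 100 uM, which is a limit of the assay and not a number. Compound 2 `COc1cccc2c1nc(-c1c(F)cccc1F)n2Cc1c(F)cccc1F` carries methoxy in place of methyl on an aromatic carbon and in this assay compound 2 gives 44.3 uM; the step is an at least 2.2-fold lower number from compound 1 to compound 2 (0.35 log units; beyond the scatter). Compound 3 `Fc1cccc(F)c1Cn1c(-c2c(F)cccc2F)nc2c(CCl)cccc21` carries chloro in place of hydrogen on a saturated chain carbon bound to an aromatic carbon, and in this assay compound 3 gives 13.4 uM; the step is an at least 7.4-fold lower number from compound 1 to compound 3 (0.87 log units; beyond the scatter). Between the two substituted compounds the step is a 3.3-fold lower number from compound 2 to compound 3 (0.52 log units; beyond the scatter).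

Compound 4 `[N-]=[N+]=NCc1cccc2c1nc(-c1c(F)cccc1F)n2Cc1c(F)cccc1F` has not yet been measured. It differs from compound 1 by azido in place of hydrogen on a saturated chain carbon bound to an aromatic carbon. Within the data shown here, the step that bears on it most directly is the one to compound 3, where a chloro entered the very same saturated chain carbon and the number fell beyond the scatter. From the compounds shown here alone, since compound 1 sits at the limit (the limit of > 100 uM in this assay, at which 1 of the 3 values shown sits), its true number is unknown, so the step from compound 1 to compound 4 can only be read as at least what the estimate says. Compound 4 is therefore expected to give about 20 uM in this assay, with a range from 6 uM to 100 uM. The corresponding expected step is an at least 5.0-fold lower number from compound 1 to compound 4 (0.69 log units; beyond the scatter).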

Compound 4, half-maximal toxic concentration: > 100 uM
Compound 4: no number, only a limit (the forecaster's own chance of this, stated with the estimate: 20%); middle value at least 5.0-fold (0.69 log units) away from the limit.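

The saturated chain carbon bound to an aromatic carbon does not respond alike to every group placed on it: azido in place of chloro gives an at least 7.4-fold higher number from compound 3 to compound 4 (0.87 log units; beyond the scatter), so the lower number of compound 3 does not extend to compound 4. Starting from the methoxy group, the change to azidomethyl gives an at least 2.2-fold higher number from compound 2 to compound 4 (0.35 log units; beyond the scatter), and among the three groups shown on this chain carbon, hydrogen, chloro and azido, only chloro goes with a measured number in this assay. Compound 1 and compound 4 both stand at a limit of the assay and not at a number, so the step between them cannot be read: the limit of > 100 uM in this assay, at which 2 of the 4 values shown sit.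

From the compounds shown here alone, how far compound 4 really lies from compound 1 remains unknown, and a single pair of groups on this carbon cannot show what separates chloro from azido. Whether bromo, a hydroxyl or an amine on the same chain carbon would follow compound 3 or compound 4 is left open, as is the effect of a longer chain carrying the chloro.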